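Swapping Ethyl for Bromo on a Sulfur-Containing Ring

This account rests on a few compounds, and the source may have more. Where it says the series, first, only, none or still open, it means among the compounds named here.

Three compounds built on one shared core were tested in an ADME assay on MDCK cells (Canis lupus familiaris) for cytotoxicity, read by microscopy, with a stated time of 48 h; a higher number here means that more compound is tolerated, a lower number that less compound is tolerated. Compound 1 `C[C@H]1[C@H](NCc2ccc(C(C)(C)C)s2)C[C@H]2C[C@@H]1C2(C)C` gives 780 nM. Compound 3 `C[C@H]1[C@H](NCc2ccc(-c3ccc(Br)s3)s2)C[C@H]2C[C@@H]1C2(C)C` differs from it only in one place and gives 780 nM; the step of no change at the digits printed from compound 1 to compound 3 (within the scatter) shows that this exchange left the reading where it was. Compound 2 `CCc1ccsc1CN[C@@H]1C[C@H]2C[C@@H]([C@H]1C)C2(C)C` gives 25000 nM, the highest of the three numbers; its gap to compound 1 and to compound 3 lies well beyond the scatter, so compound 2 is the one tolerated at the highest concentration in this set.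

Compound 4 `C[C@H]1[C@H](NCc2sccc2Br)C[C@H]2C[C@@H]1C2(C)C` has not yet been measured. It comes from compound 2 by bromo in place of ethyl on an aromatic carbon. Among the measured compounds shown here, no measured step makes this same exchange: the only measured step, from compound 1 to compound 3, swaps a different group at a different place and moved nothing, so it offers little guidance. What the data do show is that the set spans a wide range, with compound 2 standing far apart from the other two. Compound 4 is therefore expected to lie nearer compound 2 than the others, though with wide uncertainty. Compound 4 is expected to give about 12000 nM. For compound 4 the expected range runs from 3000 nM to 50000 nM. That expectation amounts to a step of a 2.1-fold lower number from compound 2 to compound 4 (0.32 log units; beyond the scatter).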

Compound 4, minimum cytotoxic concentration: 50000 nM
Compound 4: middle estimate off by 4.2-fold (0.62 log units), on the low side; low and high end bracket the measured number.
By their numbers in this assay, from the lowest: compounds 1 and 3 (each within the scatter of the next); then compounds 2 and 4 (each within the scatter of the next).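

At this place, on an aromatic carbon of a five-membered aromatic ring with 1 sulfur and next to the ring atom that bears a large group, bromo in place of ethyl gives a 2.0-fold higher number from compound 2 to compound 4 (0.30 log units; within the scatter) in this assay and so leaves the two readings indistinguishable. Among the compounds shown here, this is the first view of this position, since the only earlier step exchanged a different group at a different place: here a single bromine atom stands where ethyl's 2 carbon atoms stood, and this assay does not separate the two compounds. Nothing measured here explains this outcome.

Only ethyl and bromo are shown at this position, so it remains open whether an amine, a carboxylic acid or a longer chain such as butyl in the same place would also leave the reading within the scatter, or would shift it clearly. As far as these compounds go, it is also open whether the same exchange of ethyl for bromo would give a similar result at another carbon of the same ring, or on a different core.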